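Replacing a fluorophenyl group with a basic amine

This account rests on a few compounds, and the source may have more. Where it says the series, first, only, none or still open, it means among the compounds named here.

Compound 2 `Fc1cccc(Cn2ccc3nc(-c4ccccc4)nc-3c2)c1` is the starting point of this step. In an ADME assay on MDBK cells (Bos taurus) for cytotoxicity (on this read-out lower numbers stand for higher toxicity in this test and higher numbers for lower toxicity in this test), compound 2 gives > 100000 nM, which is a limit of the test and not a number. Compound 1 `Fc1cccc(F)c1Cn1cccc2nc(-c3c(F)cccc3F)nc1-2` in this assay gives > 100000 nM, again a limit. Compound 3 `c1ccc(-c2ccc(Cn3ccc4nc(-c5ccccc5)nc-4c3)cc2)cc1` gives 18000 nM in this assay. Compound 2 therefore sits at the limit of > 100000 nM in this assay, at which 2 of the 3 values shown sit, the upper edge of what the test can resolve. Compound 4 `CC(C)N(CCn1ccc2nc(-c3ccccc3)nc-2c1)C(C)C` differs from compound 2 in one place: (diisopropylamino)methyl in place of 3-fluorophenyl on a saturated chain carbon bound to an aromatic nitrogen. Among the measured compounds shown here, no measured step covers this change, so its direction rests on expectation alone; a modest move toward higher toxicity in this assay, a little beyond the scatter, is expected. The step of an at least 2.0-fold lower number from compound 2 to compound 4 (0.30 log units; that floor lies within the scatter) is the expected size. Compound 4 is thus estimated to give 50000 nM in this assay, between 12000 nM and 150000 nM.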

Compound 4, half-maximal cytotoxic concentration: > 100000 nM
Compound 4 ended at the assay's limit; the forecaster's own chance of this, stated with the estimate: 40%; middle value at least 2.0-fold (0.30 log units) from the limit.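

No step from compound 2 to compound 4 can be read in this assay, since both values are limits of the test: the limit of > 100000 nM in this assay, at which 3 of the 4 values shown sit.

The compounds shown leave open whether (diisopropylamino)methyl in place of 3-fluorophenyl shifts this read-out at all, and in which direction.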